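Iodo removal from compound 3: working notes

A few compounds are considered here, and "the series" means these few. Any claim that something is new, unique, unknown or untested is made for them only; others in the source may bear on it.

Of the compounds shown here, three have numbers so far in a functional assay on PC-3 cells (Homo sapiens) for inhibition, with a stated time of 48 h, tested at 50 uM; on this read-out higher numbers stand for more inhibition of growth at the one concentration tested and lower numbers for less inhibition of growth. Compound 1 `C=C[C@@](C)(/C=C/c1ccc(OC(=O)CC)cc1)CCC=C(C)C` gives 54%, and compound 2 `C=C[C@@](C)(/C=C/c1ccc(OC(=O)CCCCCCCCCCCCCCC)cc1)CCC=C(C)C` gives 62%; these two values lie within the scatter of each other. Compound 3 `CC[C@](C)(CCCC(C)C)CCc1ccc(O)c(I)c1` gives 8%, the lowest of the three and beyond the scatter from both compound 1 and compound 2. Among the compounds with values here, no two measured compounds differ in a single place, so no measured step shows what removing an iodo group does.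

The next compound is compound 4 `CC[C@](C)(CCCC(C)C)CCc1ccc(O)cc1`. The change is hydrogen in place of iodo on an aromatic carbon, ortho to a hydroxy group and meta to a large group.

Compound 3 at 8% has little room to fall on this read-out, while compound 1 at 54% shows that much higher numbers occur in the series. A rise beyond the scatter is therefore expected, though with low confidence, as compound 1 differs from compound 4 in more than one place. The expected size of the change is a number 22 percentage points higher from compound 3 to compound 4 (beyond the scatter). For compound 4 the estimate in this assay is 30%, with an expected range of 10% to 55%.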

Compound 4, percent growth inhibition at one concentration: 40%
Beside the measured number, compound 4's estimate is 10 percentage points below it; the range from low to high includes it.
By their numbers in this assay, from the lowest: compound 3; then compound 4; then compounds 1 and 2 (each within the scatter of the next).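

Hydrogen in place of iodo on an aromatic carbon, ortho to a hydroxy group and meta to a large group, gives the first single-place step in the series: in this assay the change is a number 32 percentage points higher from compound 3 to compound 4 (beyond the scatter). At this position, then, the iodo group is not required for growth inhibition at the one concentration tested, and on this pair its loss goes with a large gain rather than a loss of the read-out. Nothing measured here bears on why the step takes this direction or size.

Going by these compounds, it remains open whether this gain belongs to the removal of iodo in particular or would also appear with another group on the same aromatic carbon, such as fluoro, chloro, methyl or methoxy, which would show whether any substituent at this position goes with a low number. On these data alone, it is also open whether the same replacement would give a step of similar size on the core of compound 1, or with the hydroxy group replaced by an ester or a methoxy group.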